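Tellurium for selenium at the end of a sulfated chain

This account rests on a few compounds, and the source may have more. Where it says the series, first, only, none or still open, it means among the compounds named here.

The series carries a sulfated alkyl chain ending in a phenyl chalcogenide. Compound 1 `O=S(=O)(O)OCCCCCCCCCC[Se]c1ccccc1` and compound 3 `O=S(=O)(O)OCCCCCCCCCCC[Se]c1ccccc1` share the selenium end and differ by (sulfooxy)methyl in place of sulfooxy on a saturated chain carbon, ten or more bonds along the chain from a selenium atom. In a functional assay on HCT-116 cells (Homo sapiens) for cytotoxicity, read by MTT assay, with a stated time of 24 h (a lower number here means a stronger inhibitor, a higher number a weaker inhibitor), compound 1 gives > 100000 nM, a limit of the assay rather than a number. Compound 3 likewise gives only a limit, > 100000 nM. The step between them is therefore a step that the two limits leave unreadable from compound 1 to compound 3. Compound 2 `O=S(=O)(O)OCCCCCCCCCC[Te]c1ccccc1` differs from compound 1 by a group of 7 heavy atoms (6 carbon, 1 tellurium; one six-membered aromatic ring of carbon only) in place of a group of 7 heavy atoms (6 carbon, 1 selenium; one six-membered aromatic ring of carbon only), on a saturated chain carbon, ten or more bonds along the chain from an oxygen, and in this assay compound 2 gives 7470 nM; the step is an at least 13-fold lower number from compound 1 to compound 2 (1.12 log units; beyond the scatter), read against (the limit of > 100000 nM in this assay, at which 2 of the 3 values shown sit). Compound 4 `O=S(=O)(O)OCCCCCCCCCCC[Te]c1ccccc1` differs from compound 3 by a group of 7 heavy atoms (6 carbon, 1 tellurium; one six-membered aromatic ring of carbon only) in place of a group of 7 heavy atoms (6 carbon, 1 selenium; one six-membered aromatic ring of carbon only), on a saturated chain carbon, ten or more bonds along the chain from an oxygen, the same change at the same place. A step of similar size is expected here: an at least 12-fold lower number from compound 3 to compound 4 (1.09 log units; beyond the scatter). This rests on compound 2 giving 7470 nM and on an at least 13-fold lower number from compound 1 to compound 2 (1.12 log units; beyond the scatter). Compound 4 is estimated at 8000 nM, within 2500 nM to 40000 nM.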

Compound 4, half-maximal inhibitory concentration: 9730 nM
For compound 4 the middle estimate is 1.2-fold (0.09 log units) below the measured one; the measured number falls inside the stated range.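

In this assay, tellurium in place of selenium on the second core gives an at least 10-fold lower number from compound 3 to compound 4 (1.01 log units; beyond the scatter), so the direction of the change carries over from the first core and the step again lies beyond the scatter. What does not carry over is any statement about size, as both selenium compounds give only limits and not numbers: the same change on two cores in this assay, an at least 13-fold lower number (1.12 log units; beyond the scatter) from compound 1 to compound 2 and an at least 10-fold lower number (1.01 log units; beyond the scatter) from compound 3 to compound 4; the limit leaves it open whether they differ. With tellurium, the change in chain gives a 1.3-fold higher number from compound 2 to compound 4 (0.11 log units; within the scatter), whereas the matching step between the selenium compounds cannot be read: the limit of > 100000 nM in this assay, at which 2 of the 4 values shown sit.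

From the compounds shown here alone, whether the tellurium step holds on a longer chain remains open. So does whether it survives with a carboxylic acid or an amine in place of sulfooxy.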